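This account rests on a few compounds, and the source may have more. Where it says the series, first, only, none or still open, it means among the compounds named here.

Measured compounds:
compound 1 `CC(C)[C@H](NC(=O)CCN(C)C)c1cccc(F)c1N1CCN(C(=O)[C@@H]2CN(C(C)C)C[C@H]2c2cc(F)c(F)c(F)c2)CC1` — 250 nM
compound 2 `CCC(=O)N1C[C@@H](C(=O)N2CCN(c3ccc(C)cc3[C@@H](NC(=O)CCN(C)C)C(C)C)CC2)[C@H](c2ccc(Cl)cc2)C1` — 4.6 nM

In an assay on HEK293 cells for displacement of a labelled ligand from Melanocortin receptor 4 (Homo sapiens) (on this read-out higher numbers stand for weaker inhibition and lower numbers for stronger inhibition), compound 1 gives 250 nM, the higher of the two numbers in hand. Compound 2 gives 4.6 nM in this assay; the two differ in several places at once, so the gap between them is not assigned to any single change and is taken only as what the two values show.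

Compound 3 `CC(C)[C@H](NC(=O)CCN(C)C)c1cccc(F)c1N1CCN(C(=O)[C@@H]2CN(C(C)C)C[C@H]2c2ccc(Cl)cc2)CC1` is not yet measured. It differs from compound 1 in one place: 4-chlorophenyl in place of 3,4,5-trifluorophenyl on a saturated ring carbon. The 4-chlorophenyl group that enters is the same aryl group carried by compound 2, while the rest of compound 3 stays as in compound 1. Going by the values given here, no step between measured compounds isolates this change, so the direction is an expectation only. Since compound 2, the carrier of the 4-chlorophenyl group, gives 4.6 nM, a move toward stronger inhibition is expected for compound 3, of moderate size, beyond the scatter but short of the whole gap between compound 1 and compound 2. The expected step is a 4.2-fold lower number from compound 1 to compound 3 (0.62 log units; beyond the scatter). Compound 3 is estimated at 60 nM, with a range from 15 nM to 250 nM.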

Compound 3, inhibition constant: 5.3 nM
For compound 3 the middle estimate is 11-fold (1.05 log units) above the measured one, outside the stated range (below it).
By their numbers in this assay, from the lowest: compounds 2 and 3 (each within the scatter of the next); then compound 1.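

The step of a 47-fold lower number from compound 1 to compound 3 (1.67 log units; beyond the scatter) in this assay shows that the aryl group on this saturated ring carbon, two ring bonds from the ring nitrogen, is a position where the read-out moves strongly. Going by these compounds alone, it is the only step so far that isolates one change, and it shows that 4-chlorophenyl in place of 3,4,5-trifluorophenyl is enough on its own for a large move toward stronger inhibition, with the rest of the core of compound 1 held fixed, including the isopropyl group on the ring atom that bears it. No measurement at hand accounts for this step, so the part played by the chlorine and the part played by the three fluorines stay apart from any explanation.

Whether the step depends on chlorine itself stays open, since the compounds shown carry no bromine, lone fluorine or methyl group on this aryl ring in its place. Also open, going by these compounds, is whether the same exchange gives a step of similar size on other groups at the ring nitrogen, such as a cyclopropylcarbonyl group or a longer acyl chain.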